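A Second Chloro on the Shared Core

A few compounds are considered here, and "the series" means these few. Any claim that something is new, unique, unknown or untested is made for them only; others in the source may bear on it.

Measured compounds:
compound 1 `ClCc1ccc(Cn2cnc3c(Cl)ncnc32)cc1` gives 10200 nM
compound 2 `ClCc1cccc(Cn2cnc3ncnc(Cl)c32)c1` gives 18200 nM

Both were tested in a functional assay on Hs-578T cells (Homo sapiens) for cytotoxicity, read by sulforhodamine B assay, with a stated time of 48 h; a higher number here means a weaker inhibitor of growth, a lower number a stronger inhibitor of growth. Of the two numbers, that of compound 2 is the higher, but the two lie within the usual scatter of each other, so no order between compound 1 and compound 2 can be read from them.

Compound 3 `ClCc1cccc(Cn2cnc3nc(Cl)nc(Cl)c32)c1` differs from compound 2 in one place: chloro in place of hydrogen on an aromatic carbon. The new chloro sits between two ring nitrogen atoms of the six-membered aromatic ring that already carries a chloro group, meta to that chloro group, meta to a fused ring and para to a fused ring.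

Among the measured compounds shown here, no pair of measured compounds shows what a change of this kind does in this assay, and the two measured numbers themselves do not separate. Compound 3 is therefore expected to stay close to compound 2, with a step of about a 1.2-fold lower number from compound 2 to compound 3 (0.08 log units; within the scatter), which is no more than the scatter allows. In this assay compound 3 is estimated at 15000 nM, with a likely range from 5000 nM to 45000 nM.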

Compound 3, concentration for 50% growth inhibition: 1410 nM
The estimate for compound 3 lay 11-fold (1.03 log units) above the measured number; the measured number lies below the stated range.
By their numbers in this assay, from the lowest: compound 3; then compounds 1 and 2 (each within the scatter of the next).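

In this assay the entry of chloro in place of hydrogen on the aromatic carbon between two ring nitrogen atoms brings a 13-fold lower number from compound 2 to compound 3 (1.11 log units; beyond the scatter) and is the only step shown in this series. This carbon carries hydrogen in both compound 1 and compound 2, so those compounds gave no sign of what a substituent there could do; compound 3 shows that this single added chlorine atom, with the rest of compound 2 unchanged, moves the number well beyond the scatter. No measurement shown bears on what lies behind this step.

From the compounds shown here alone, whether the step belongs to chloro in particular or would also appear with another group on this carbon, such as an amine, a methoxy group or a fluoro group, remains open. Going by these compounds, it also remains open whether the same change would give a step of similar size on compound 1, where the chloromethyl group and the benzyl attachment to the core are arranged differently, and whether the step would hold in other cell lines.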